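This account rests on a few compounds, and the source may have more. Where it says the series, first, only, none or still open, it means among the compounds named here.

Compound 2 `COc1ccc(C(=O)N2CCC(n3cncc3-c3ccc(OS(=O)(=O)c4cccc5cnccc45)cc3)CC2)cc1OC` is measured in an assay on HEK293 cells for antagonist activity at P2X purinoceptor 7 (Homo sapiens), read by fluorescence, with a stated time of 2 h (a higher number here means a weaker inhibitor, a lower number a stronger inhibitor), at 259 nM, the lower of the two numbers recorded so far. Compound 1 `Nc1cccc(S(=O)(=O)Oc2ccc(-c3cncn3C3CCN(C(=O)c4ccc(Cl)c(C(F)(F)F)c4)CC3)cc2)c1` gives 565 nM in this assay, a gap that lies beyond the scatter. Compound 3 `CC(C)(O)c1ccc(C(=O)N2CCC(n3cncc3-c3ccc(OS(=O)(=O)c4cccc5cnccc45)cc3)CC2)cc1` has not yet been measured; it differs from compound 2 in a single place, (4-(1-hydroxy-1-methylethyl)phenyl in place of 3,4-dimethoxyphenyl on a carbonyl carbon). Going by the values given here, no measured pair shows this change, so nothing here points to a direction. The step of a 1.0-fold lower number from compound 2 to compound 3 (0.02 log units; within the scatter) is expected to stay within the scatter, in either direction. Compound 3 is therefore estimated at 250 nM, with a likely range from 90 nM to 700 nM.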

Compound 3, half-maximal inhibitory concentration: 109 nM
Estimate against measurement, compound 3: 2.3-fold (0.36 log units) above; low and high end bracket the measured number.
By their numbers in this assay, from the lowest: compound 3; then compound 2; then compound 1.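

In this assay, the change from 3,4-dimethoxyphenyl to 4-(1-hydroxy-1-methylethyl)phenyl on the carbonyl carbon gives a 2.4-fold lower number from compound 2 to compound 3 (0.38 log units; beyond the scatter), so the group at this position does affect the number, if only modestly. The entering group carries 1 hydrogen-bond donor where the leaving group has 0, but no measurement bears on why the number fell. The compounds shown do not separate the hydroxyl from the rest of the entering group. A simple isopropyl, a carboxylic acid or an amine in its place remains to be compared.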